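Thioether coumarin series: aryl swap at the benzylic sulfur

This account rests on a few compounds, and the source may have more. Where it says the series, first, only, none or still open, it means among the compounds named here.

Compound 1 `Cc1cc(=O)oc2cc(SCc3cccnc3)ccc12` carries a pyridin-3-yl group on a saturated chain carbon bound to a sulfur. In a functional assay on KB cells (Homo sapiens) for antiproliferative activity, read by sulforhodamine B assay, with a stated time of 72 h (a lower number here means a stronger inhibitor of growth, a higher number a weaker inhibitor of growth), compound 1 gives > 35200 nM, which is a limit of the assay and not a number. Compound 2 `Cc1cc(=O)oc2cc(SCc3cccc(C(F)(F)F)c3)ccc12` is the trifluoromethyl-bearing member of the same series. In this assay compound 2 gives > 28500 nM, again a limit rather than a measured number. Within the data shown here, both values shown sit at limits (the limit of > 28500 nM in this assay, at which 1 of the 2 values shown sits, (the limit of > 35200 nM in this assay, at which 1 of the 2 values shown sits)), so compound 1 stands nowhere relative to a measured neighbour, and no step between measured compounds can be computed.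

Compound 3 `Cc1cccc(CSc2ccc3c(C)cc(=O)oc3c2)c1` differs from compound 1 by 3-methylphenyl in place of pyridin-3-yl on a saturated chain carbon bound to a sulfur. Among the measured compounds shown here, no measured step covers a change of this kind. The step from compound 1 to compound 3 is expected to be none beyond the scatter, a step that the limit leaves unreadable from compound 1 to compound 3, because the limit of > 28500 nM in this assay, at which 1 of the 2 values shown sits, and the limit of > 35200 nM in this assay, at which 1 of the 2 values shown sits, are the only points available and both are limits. Compound 3 is accordingly estimated at 40000 nM in this assay, within 10000 nM to 120000 nM, with a substantial chance that the assay again reports only a limit.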

Compound 3, concentration for 50% growth inhibition: > 33700 nM
Compound 3: only a limit was reported; the forecaster's own chance of this, stated with the estimate: 75%; the middle value does not contradict the limit.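

Compound 3 gives > 33700 nM in this assay as a limit and not a number. With compound 1 and compound 2 also at limits, no step among these three compounds can be read. The compounds shown leave open whether in this assay any group on the saturated chain carbon bound to a sulfur gives a number rather than a limit.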